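This account rests on a few compounds, and the source may have more. Where it says the series, first, only, none or still open, it means among the compounds named here.

Compound 2, `CS(=O)(=O)N(C[C@H](O)C(=O)NO)c1ccc(Sc2ccc(F)cc2)cc1`, stands at the higher of the two numbers in hand: in an assay on isolated protein for inhibition of matrix metalloproteinase-9 (Homo sapiens) (a higher number here means a weaker inhibitor, a lower number a stronger inhibitor), compound 2 gives 104 nM, while compound 1, `Cc1ccc(Oc2ccc(N(C[C@H](O)C(=O)NO)S(=O)(=O)Cc3cccnc3)cc2)cc1`, gives 69 nM, a gap that lies within the scatter. Compound 3, `CS(=O)(=O)N(C[C@H](O)C(=O)NO)c1ccc(C#Cc2ccc(Cl)cc2)cc1`, differs from compound 2 by 2-(4-chlorophenyl)ethynyl in place of (4-fluorophenyl)sulfanyl on an aromatic carbon. Going by the values given here, no step between measured compounds covers a change of this kind, so its size is uncertain; on the two numbers in hand, no shift beyond the scatter is expected in either direction. Compound 3 is estimated at 85 nM in this assay, with a range from 20 nM to 400 nM. That estimate means an expected step of a 1.2-fold lower number from compound 2 to compound 3 (0.09 log units; within the scatter).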

Compound 3, half-maximal inhibitory concentration: 47 nM
The estimate for compound 3 lay 1.8-fold (0.26 log units) above the measured number; measured number inside the range.
By their numbers in this assay, from the lowest: compounds 3, 1 and 2 (each within the scatter of the next, the first and the last beyond it).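

In this assay, putting 2-(4-chlorophenyl)ethynyl in place of (4-fluorophenyl)sulfanyl on this aromatic carbon gives a 2.2-fold lower number from compound 2 to compound 3 (0.34 log units; beyond the scatter), so the position accepts a triple bond instead of the sulfur, with a stronger inhibitor as the result. The change swaps the halogen as well, so the step belongs to the two together. Nothing available explains the step. From the compounds shown here alone, whether the triple bond or the chlorine carries the step stays open. Also open, going by these compounds, is how an amine or a carboxylic acid in place of the chlorine would compare.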